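The compounds below may be only part of what the source reports. "The series", "measured", "known", "first", "only" and "open" are said of these compounds alone.

In a functional assay on OVCAR-3 cells (Homo sapiens) for inhibition, read by sulforhodamine B assay, with a stated time of 48 h (on this read-out higher numbers stand for weaker inhibition of growth and lower numbers for stronger inhibition of growth), compound 1 `CC(C)(C)NCc1c(C(=O)O)nn(-c2ccccc2)c1-c1ccccc1` gives no number, only a limit of > 716000 nM. Among the compounds with values here, compound 2 `CC(C)(C)NCc1c(C(=O)O)nn(-c2ccc(Cl)cc2)c1-c1ccc(Cl)cc1` therefore holds the only true number so far, with 84900 nM. Compound 3 `CC(C)(C)NCc1c(C(=O)O)nn(-c2ccc(Cl)cc2)c1-c1ccccc1` differs from compound 2 by hydrogen in place of chloro on an aromatic carbon, with hydrogen in place of chloro on an aromatic carbon, para to a large group. The 4-chlorophenyl thus becomes phenyl, while the other chloro stays. Within the data shown here, no measured single-change step is available as a guide. Among the measured compounds shown here, the only hint is that compound 1, which carries no chloro, sits at the limit of > 716000 nM. A moderate move in this assay toward a higher number, meaning weaker inhibition of growth, is therefore expected. The estimated change is a 2.7-fold higher number from compound 2 to compound 3 (0.43 log units; beyond the scatter). For compound 3 the expected value is 230000 nM, with an estimated range from 100000 nM to 600000 nM.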

Compound 3, concentration for 50% growth inhibition: 653000 nM
For compound 3 the middle estimate is 2.8-fold (0.45 log units) below the measured one, and the stated range ends below it.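

Within the data shown here, with the other chloro kept, the change from 4-chlorophenyl to phenyl gives in this assay a 7.7-fold higher number from compound 2 to compound 3 (0.89 log units; beyond the scatter), the first single-change step, so this one chloro, para to a large group, counts on its own. What the remaining chloro contributes is less clear: an at least 1.0-fold lower number from compound 1 to compound 3 (0.03 log units; that floor lies within the scatter) offers only a floor, so the size of that step cannot be read. The value of compound 1 is a limit, not a number: the limit of > 716000 nM in this assay, at which 1 of the 3 values shown sits.

As far as these compounds go, whether fluoro, bromo, methyl or methoxy at this position would match chloro remains open. From the compounds shown here alone, it is also open whether chloro at this position gives the same step when the other ring carries plain phenyl, or when the carboxylic acid is replaced by a methyl ester.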